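Swapping fluoro for bromo: expecting little change

The source may report more compounds than this note shows. Statements on the series, on what has been measured and on what is new or still open speak of the compounds shown alone.

Compound 1 `COc1cccc(/C=C/C(=O)c2c(OC)cc(OC)cc2OC)c1` gives 40% in a functional assay on Huh-7 cells (Homo sapiens), read by fluorescence and BrdU incorporation, with a stated time of 48 h, tested at 10 uM; on this read-out lower numbers stand for a stronger effect and higher numbers for a weaker effect at the one concentration tested.
Compound 2 `COc1cc(OC)c(C(=O)/C=C/c2ccccc2)c(OC)c1` gives 45%.
Compound 3 `COc1cc(OC)c(C(=O)/C=C/c2ccc(F)cc2)c(OC)c1` gives 44%.

Compound 3 holds the second highest of the three numbers, but it cannot be separated from its neighbours: the step of a number 1 percentage points lower from compound 2 to compound 3 (within the scatter) and the step of a number 4 percentage points higher from compound 1 to compound 3 (within the scatter) both lie within the scatter, so on these numbers the three compounds behave alike. The shared core carries three methoxy groups, and the changes so far concern only the ring at the far end of the double-bonded chain.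

Compound 4 `COc1cc(OC)c(C(=O)/C=C/c2ccc(Br)cc2)c(OC)c1` differs from compound 3 in one place: bromo in place of fluoro on an aromatic carbon. Within the data shown here, two measured steps bear on it. Adding a fluoro to that aromatic carbon gave a number 1 percentage points lower from compound 2 to compound 3 (within the scatter), and exchanging the whole aromatic group gave a number 4 percentage points higher from compound 1 to compound 3 (within the scatter); neither moved the read-out beyond the scatter. Nothing measured shows a bromo, so the expectation rests on halogen and aromatic changes leaving the number where it was. The expected step is therefore a number 1 percentage points lower from compound 3 to compound 4 (within the scatter), with no direction beyond the scatter. Compound 4 is estimated at 43%, with a range of 28% to 58%.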

Compound 4, a percentage reported as activity, at one concentration (the size of the read-out at that concentration, not a potency): 46%
Estimate against measurement, compound 4: 3 percentage points below, within the range that was stated.
By their numbers in this assay, from the lowest: compounds 1, 3, 2 and 4 (each within the scatter of the next).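

In this assay, the aromatic carbon para to a large group accepts bromo as readily as fluoro, with the exchange leaving no readable effect (a number 2 percentage points higher from compound 3 to compound 4 (within the scatter)), and bromo in place of hydrogen leaves none either (a number 1 percentage points higher from compound 2 to compound 4 (within the scatter)). The earlier compounds shown here showed this only for fluoro, so the flat picture at this position now holds for a second halogen, one that is a different element from fluorine though it also counts as a single heavy atom. Replacing the whole end group, with 4-bromophenyl in place of 3-methoxyphenyl, also stays within the usual variation between repeats (a number 6 percentage points higher from compound 1 to compound 4 (within the scatter)), and nothing available explains why these groups behave alike.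

From the compounds shown here alone, the groups compared at this position are only hydrogen, fluoro and bromo, so it remains open whether an amine, a carboxylic acid or a longer chain there would move the number beyond the scatter. The methoxy groups on the shared core stay the same throughout these compounds, which leaves open what a hydroxyl in place of one of them would do.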